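The source may hold more compounds than are shown below. What is called first, only, known or untested is meant among the compounds shown, and "the series" means these compounds.

In an ADME assay on CHO cells (Cricetulus griseus) for cytotoxicity, read by LDH release (a higher number here means a weaker inhibitor, a lower number a stronger inhibitor), three amides on a shared core have been measured. Compound 1 `CCCC(NC(=O)C(C)Oc1ccc(Cl)cc1Cl)c1ccc(F)cc1` gives > 100000 nM, which is a limit of the assay and not a number. Compound 2 `CC(Oc1ccc(Cl)cc1Cl)C(=O)NC(c1ccc(F)cc1)C(C)C` gives > 100000 nM, likewise a limit. Among the measured compounds shown here, compound 3 `CC(Oc1ccc(Cl)cc1Cl)C(=O)NC(CO)c1ccc(F)cc1` gives 18000 nM, the only true number of the three.

Compound 4 `COC(=O)C(NC(=O)C(C)Oc1ccc(Cl)cc1Cl)c1ccc(F)cc1` carries methoxycarbonyl in place of hydroxymethyl on a saturated chain carbon bound to an amide-type nitrogen and an aromatic carbon.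

For the measured compounds named here, two measured steps bear on this change. Both end at compound 3 and start from a limit, so they give only a minimum size: an at least 5.5-fold lower number from compound 1 to compound 3 (0.74 log units; beyond the scatter), and an at least 5.5-fold lower number from compound 2 to compound 3 (0.74 log units; beyond the scatter). Compound 4 gives up the hydroxymethyl of compound 3, so its number is expected to move back toward that limit, but neither compound 1 nor compound 2 carries a methoxycarbonyl, which leaves the size uncertain. The expected step is a 2.8-fold higher number from compound 3 to compound 4 (0.44 log units; beyond the scatter), toward a higher number. The estimate for compound 4 is 50000 nM, with an expected range of 15000 nM to 100000 nM.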

Compound 4, half-maximal inhibitory concentration: > 100000 nM
Compound 4: no number, only a limit (the forecaster's own chance of this, stated with the estimate: 35%); middle value at least 2.0-fold (0.30 log units) away from the limit.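

In this assay, among the compounds shown here, the step to methoxycarbonyl on this saturated chain carbon is an at least 5.5-fold higher number from compound 3 to compound 4 (0.74 log units; beyond the scatter), so a group carrying oxygen at this place does not by itself give a lower number, which the carbon chains of the earlier compounds could not show. Compound 4 gives a limit and not a number, the same limit as compound 1 and compound 2: the limit of > 100000 nM in this assay, at which 3 of the 4 values shown sit. The steps from compound 1 and from compound 2 to compound 4 join two limits and cannot be read.

Going by these compounds, whether a methoxymethyl group, a carboxylic acid or an aminomethyl group at this carbon would give a true number remains open. Also open, on these data alone, is how compound 1, compound 2 and compound 4 would order among themselves, since the limit hides any difference.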